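The compounds below may be only part of what the source reports. "The series", "measured", "known", "first", "only" and "open" are said of these compounds alone.

Measured in a physicochemical assay, with a stated time of 6 min; a higher number here means a weaker inhibitor, a lower number a stronger inhibitor:
- compound 1 `Cc1ccc(NC(=O)Nc2nc(-c3cc4cc(Br)ccc4o3)cs2)cc1` gives > 200000 nM (a limit)
- compound 2 `COc1ccc(NC(=O)Nc2nc(-c3cc4ccccc4o3)cs2)cc1` gives 17400 nM
- compound 3 `O=C(Nc1cccc([N+](=O)[O-])c1)Nc1nc(-c2cc3cc(Br)ccc3o2)cs1` gives 159000 nM

Compound 3 holds the higher of the two actual numbers at 159000 nM, while compound 2 stands lower at 17400 nM. Compound 1 gives > 200000 nM, which is a limit of the assay and not a number.

The next compound is compound 4 `COc1ccc(NC(=O)Nc2nc(-c3cc4cc(Br)ccc4o3)cs2)cc1`, with 4-methoxyphenyl in place of 3-nitrophenyl on an amide-type nitrogen. One measured step changes the same place: an at least 1.2-fold lower number from compound 1 to compound 3 (0.09 log units; that floor lies within the scatter). It starts from a limit and its floor lies within the scatter, so it fixes no size for the present change. Some further guidance comes from compound 2 at 17400 nM, which carries the same 4-methoxyphenyl on a different core. On that basis a moderate move to a lower number is expected in this assay, though compound 1 keeps the upper end open and the range stays wide. The estimated change is a 2.3-fold lower number from compound 3 to compound 4 (0.36 log units; beyond the scatter). The expected value for compound 4 is 70000 nM, with an estimated range from 20000 nM to 200000 nM.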

Compound 4, half-maximal inhibitory concentration: > 200000 nM
Compound 4 ended at the assay's limit (the forecaster's own chance of this, stated with the estimate: 20%); at least 2.8-fold (0.45 log units) between middle value and limit.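

In this assay, the change at the amide-type nitrogen reads an at least 1.2-fold higher number from compound 3 to compound 4 (0.09 log units; that floor lies within the scatter), so swapping 3-nitrophenyl for 4-methoxyphenyl on the bromo-bearing core gets no size, and the floor gives no order beyond the scatter. The one readable effect sits elsewhere: bromo in place of hydrogen on an aromatic carbon, with 4-methoxyphenyl held constant, gives an at least 11-fold higher number from compound 2 to compound 4 (1.06 log units; beyond the scatter), a large step and the first in this set that is printed as beyond the scatter. The step between compound 1 and compound 4, methoxy in place of methyl on an aromatic carbon, cannot be read because both ends are limits: the limit of > 200000 nM in this assay, at which 2 of the 4 values shown sit.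

On these data alone, only the 4-methoxyphenyl pair shows both the hydrogen and the bromo form, so it remains open whether the bromo step has a similar size with 3-nitrophenyl or 4-methylphenyl on the amide-type nitrogen. Also open, as far as these compounds go, is how this assay would read with chloro or an amine in place of the bromo on that aromatic carbon, which would show whether the step is specific to bromo.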